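Benzylamino nucleoside analogues in the MCF antiproliferation assay

The source may hold more compounds than are shown below. What is called first, only, known or untested is meant among the compounds shown, and "the series" means these compounds.

Compound 1 `OC[C@H]1O[C@@H](n2cnc3c(NCc4cccc(Br)c4)ncnc32)[C@H](O)[C@@H]1O`: > 166000 nM in a functional assay on MCF cells (Homo sapiens) for antiproliferative activity, with a stated time of 72 h (on this read-out lower numbers stand for stronger inhibition and higher numbers for weaker inhibition), a limit of the assay.
Compound 2 `COc1ccc(CNc2ncnc3c2ncn3[C@@H]2O[C@H](CO)[C@@H](O)[C@H]2O)c(OC)c1`: > 166000 nM in this assay, a limit of the assay.

Compound 2 stands at a limit only, so no number places it relative to anything else in this assay. For the measured compounds named here, both values so far sit at the same limit, (the limit of > 166000 nM in this assay, at which 2 of the 2 values shown sit), which is all the series shows at present. Going by the values given here, the one measured step, a step that the two limits leave unreadable from compound 1 to compound 2, cannot be read, since both ends are limits.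

Compound 3 `Cc1ccc(O)c(CNc2ncnc3c2ncn3[C@@H]2O[C@H](CO)[C@@H](O)[C@H]2O)c1` differs from compound 2 in one place: 2-hydroxy-5-methylphenyl in place of 2,4-dimethoxyphenyl on a saturated chain carbon bound to a nitrogen on an aromatic ring. Among the compounds with values here, no measured step bears readably on this change, so there is nothing from which a direction or size could be derived; the only guide is that every value shown so far is a limit.

Compound 3 is therefore expected to give a value near or at that same limit in this assay, estimated at 200000 nM with a range from 40000 nM to 1000000 nM. The step from compound 2 to compound 3 is expected to be a step that the limit leaves unreadable from compound 2 to compound 3, with the real chance that compound 3 again returns only a limit.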

Compound 3, half-maximal inhibitory concentration: > 166000 nM
Compound 3: no number, only a limit; the forecaster's own chance of this, stated with the estimate: 75%; the middle value does not contradict the limit.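

No step among compound 1, compound 2 and compound 3 can be read in this assay, since all three stand at the same limit of the assay: the limit of > 166000 nM in this assay, at which 3 of the 3 values shown sit.

The compounds shown leave open what real value each of the three has, and whether the 3-bromophenyl, 2,4-dimethoxyphenyl and 2-hydroxy-5-methylphenyl groups differ at all on this read-out.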